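A few compounds are considered here, and "the series" means these few. Any claim that something is new, unique, unknown or untested is made for them only; others in the source may bear on it.

In an assay on the whole organism (plasma, strain Sprague-Dawley) for inhibition of Dipeptidyl peptidase 4 (Rattus norvegicus), with a stated time of 6 h, at a dose of 1 mg/kg by the oral route (on this read-out higher numbers stand for more inhibition at the one dose given (going by the name of the read-out) and lower numbers for less inhibition), compound 3 `CCN(C)C(=O)[C@H]1C[C@@H](C(=O)N2CCC[C@H]2C#N)N[C@H]1C` gives 92%, the highest of the three numbers recorded here. Compound 1 `N#C[C@@H]1CCCN1C(=O)[C@@H]1C[C@H](C(=O)N2CCOCC2)CN1` gives 73% and compound 2 `N#C[C@@H]1CCCN1C(=O)[C@@H]1C[C@H](CO)CN1` gives 64%, and both of these stand beyond the scatter below compound 3. Compound 4 `C[C@@H]1N[C@H](C(=O)N2CCC[C@H]2C#N)C[C@@H]1C(=O)N1CCSCC1` has not yet been measured. It differs from compound 3 in one place (thiomorpholin-4-yl in place of ethyl(methyl)amino on a carbonyl carbon). For the measured compounds named here, no pair of measured compounds shows this change on its own, and compound 1 and compound 2 differ from compound 3 in more than that one place, so the expectation rests on the values shown alone. The step from compound 3 to compound 4 is expected to be a number 6 percentage points lower from compound 3 to compound 4 (within the scatter), a shift not beyond the scatter. Compound 4 is therefore estimated at 86%, with a range from 72% to 96%.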

Compound 4, a percentage reported as inhibition, in the whole organism at one dose (the size of the read-out at that dose, not a potency): 92%
The estimate for compound 4 lay 6 percentage points below the measured number, within the range that was stated.
By their numbers in this assay, from the lowest: compounds 2 and 1 (each within the scatter of the next); then compounds 3 and 4 (each within the scatter of the next).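

In this assay, putting thiomorpholin-4-yl in place of ethyl(methyl)amino on a carbonyl carbon gives no change at the digits printed from compound 3 to compound 4 (within the scatter). For the compounds shown here, the earlier compounds offered no comparison differing in one place, so this is the first direct reading at this position, and here an open amine group and a six-membered ring containing sulfur read alike. Nothing measured here explains the result.

From the compounds shown here alone, it remains open how a piperidin-1-yl ring or a dipropylamino group would read on the same carbonyl carbon. Going by these compounds, whether compound 3 and compound 4 would still read alike at another dose or time also remains open.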